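Trading a cyclohexyl group for an allyl carbamate

A few compounds are considered here, and "the series" means these few. Any claim that something is new, unique, unknown or untested is made for them only; others in the source may bear on it.

Three nucleosides built on one shared core differ only in the group hanging from the oxygen on the sugar's side chain. In an assay on DDT1 cells (Cricetulus griseus) for binding affinity to adenosine receptor A1 (Homo sapiens), read by radioligand binding (a higher number here means a weaker inhibitor, a lower number a stronger inhibitor), compound 1 `CC/N=C(\S)OC[C@H]1OC(n2cnc3c(NC4CCOC4)ncnc32)[C@H](O)[C@@H]1O` gives 33 nM. Compound 2 `O[C@@H]1[C@@H](CO/C(S)=N/C2CC2)OC(n2cnc3c(NC4CCOC4)ncnc32)[C@@H]1O` gives 157 nM, and compound 3 `O[C@@H]1[C@@H](CO/C(S)=N/C2CCCCC2)OC(n2cnc3c(NC4CCOC4)ncnc32)[C@@H]1O` gives 253 nM. Compound 3 carries the highest number of the three: the step of a 7.7-fold higher number from compound 1 to compound 3 (0.88 log units; beyond the scatter) lies beyond the scatter, while a 1.6-fold higher number from compound 2 to compound 3 (0.21 log units; within the scatter) stays within it, so compounds 2 and 3 cannot be told apart. The step of a 4.8-fold higher number from compound 1 to compound 2 (0.68 log units; beyond the scatter) shows the same tendency, a ring on the double-bonded nitrogen in place of an ethyl chain giving a higher number.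

Compound 4 `C=CCNC(=O)OC[C@H]1OC(n2cnc3c(NC4CCOC4)ncnc32)[C@H](O)[C@@H]1O` has not yet been measured. Going from compound 3 to compound 4, (a group of 6 heavy atoms (4 carbon, 1 nitrogen, 1 oxygen; no ring) in place of a group of 9 heavy atoms (7 carbon, 1 nitrogen, 1 sulfur; one six-membered non-aromatic ring of carbon only), on an oxygen on a saturated carbon). Among the compounds with values here, no measured step matches this exchange exactly, and the link to the oxygen is itself new, which widens the uncertainty. Because a 7.7-fold higher number from compound 1 to compound 3 (0.88 log units; beyond the scatter) and a 4.8-fold higher number from compound 1 to compound 2 (0.68 log units; beyond the scatter) both favoured the short ethyl chain over a ring, and allyl is likewise a short chain, a lower number is expected for compound 4. Compound 4 is therefore estimated to give 60 nM, between 15 nM and 250 nM, an expected step of a 4.2-fold lower number from compound 3 to compound 4 (0.62 log units; beyond the scatter).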

Compound 4, inhibition constant: 524 nM
Compound 4: the middle estimate sits 8.7-fold (0.94 log units) below what was measured; measured number outside the range, above it.
By their numbers in this assay, from the lowest: compound 1; then compounds 2 and 3 (each within the scatter of the next); then compound 4.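

In this assay, compound 4 shows that a short chain without a ring does not by itself give a low number at this position: allylcarbamoyl gives a 2.1-fold higher number from compound 3 to compound 4 (0.32 log units; beyond the scatter) and a 3.3-fold higher number from compound 2 to compound 4 (0.52 log units; beyond the scatter), so the ringless group stands above both ring-bearing compounds, against the pattern of the first three. The largest change comes against the other ringless compound, with a 16-fold higher number from compound 1 to compound 4 (1.20 log units; beyond the scatter), and here the exchange alters more than the chain, as the sulfur-bearing link of compound 1 gives way to the carbonyl of allylcarbamoyl. No measurement here explains why this exchange raises the number.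

The compounds shown do not separate the part played by the link from that played by the chain, and an ethylcarbamoyl group on the same oxygen would keep the ethyl chain of compound 1 while changing only the link. As far as these compounds go, whether an allyl chain on the sulfur-bearing link would stay close to the ethyl chain of compound 1, or whether a longer chain such as butyl would be tolerated there, also remains open.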